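This account rests on a few compounds, and the source may have more. Where it says the series, first, only, none or still open, it means among the compounds named here.

Measured compounds in an ADME assay on HEL cells (Homo sapiens) for cytotoxicity, with a stated time of 3 days; a higher number here means that more compound is tolerated, a lower number that less compound is tolerated:
compound 1 `CCC1(Cc2ccccc2)OS(=O)(=O)C=C1OCC#N` gives > 400000 nM
compound 2 `CCCC1(Cc2ccccc2)OS(=O)(=O)C=C1OCc1ccccc1` gives >= 400000 nM
compound 3 `CC(C)CC1(Cc2ccccc2)OS(=O)(=O)C=C1OCc1ccccc1` gives >= 80000 nM

Each of these three results is a limit of the assay and not a measured number, so none of them can be ranked against the others. Compound 1 stands at the limit of > 400000 nM in this assay, at which 1 of the 3 values shown sits. Compound 4 `CCC1(Cc2ccccc2)OS(=O)(=O)C=C1OCC=C(C)C` differs from compound 1 by a single change: 2-methylprop-1-en-1-yl in place of cyano on a saturated chain carbon bound to an oxygen on an unsaturated carbon. Among the measured compounds shown here, the only step recorded between measured compounds, a step that the two limits leave unreadable from compound 2 to compound 3, concerns a different place on the shared core, and its size cannot be read from the two limits, so no measured step bears directly on the change from compound 1 to compound 4. With compound 1 sitting at a limit and nothing pointing the other way, no step beyond the scatter in this assay is expected, and the estimated step of a number no higher from compound 1 to compound 4 (the limit leaves the size open) is small. Compound 4 is therefore expected to give about 400000 nM in this assay, within a range from 150000 nM to 400000 nM, most likely again as a limit rather than a number.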

Compound 4, minimum cytotoxic concentration: 400000 nM
The estimate for compound 4 equals the measured number at the digits printed; the range from low to high includes it.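

In this assay, among the compounds shown here, compound 4 gives 400000 nM, the first value in this set that is a number and not a limit of the assay. Compound 1 gives > 400000 nM, which is a limit. Placing 2-methylprop-1-en-1-yl instead of cyano, on a saturated chain carbon bound to an oxygen on an unsaturated carbon, gives a number no higher from compound 1 to compound 4 (the limit leaves the size open), so this position can carry a group of 4 carbon atoms with no hydrogen-bond acceptor, and the result is a number, although the size of the step cannot be read.

The compounds shown leave open what a group of another kind at this place, such as an amine or a carboxylic acid, would give in this assay. Also open, from the compounds shown here alone, is what a longer saturated chain would give there.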